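The source may hold more compounds than are shown below. What is called first, only, known or untested is meant among the compounds shown, and "the series" means these compounds.

Compound 1 `Cc1ccc(-c2cn(-c3ccc(CN4CCN(C)CC4)cc3)nn2)cc1Nc1nccc(-c2cccnc2)n1`: a functional assay on K562 cells (Homo sapiens) for inhibition, read by MTT assay, with a stated time of 72 h (a higher number here means a weaker inhibitor, a lower number a stronger inhibitor), 4700 nM
Compound 2 `Cc1ccc(-c2cn(-c3ccc(CN4CCN(C)CC4)c(C(F)(F)F)c3)nn2)cc1Nc1nccc(-c2cccnc2)n1`: this assay 30 nM

Among the compounds with values here, compound 1 stands with the higher of the two numbers measured; the only measured step is a 160-fold lower number from compound 1 to compound 2 (2.19 log units; beyond the scatter), a change of trifluoromethyl for hydrogen that is not the change considered here. Compound 3 `CCN(CC)c1ccc(-n2cc(-c3ccc(C)c(Nc4nccc(-c5cccnc5)n4)c3)nn2)cc1` differs from compound 1 by diethylamino in place of (4-methylpiperazin-1-yl)methyl on an aromatic carbon. Within the data shown here, no measured step bears on this exchange, so no step beyond the scatter is expected, and the range given is wide. Compound 3 is expected at 6000 nM, between 1500 nM and 25000 nM, which means an expected step of a 1.3-fold higher number from compound 1 to compound 3 (0.11 log units; within the scatter).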

Compound 3, half-maximal inhibitory concentration: > 30000 nM
Compound 3: a limit, no number; the forecaster's own chance of this, stated with the estimate: 10%; middle value at least 5.0-fold (0.69 log units) away from the limit.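

In this assay, diethylamino in place of (4-methylpiperazin-1-yl)methyl gives an at least 6.3-fold higher number from compound 1 to compound 3 (0.80 log units; beyond the scatter). Within the data shown here, compounds 1 and 2 share (4-methylpiperazin-1-yl)methyl, so this is the first sign that the group on this aromatic carbon itself matters, even without trifluoromethyl. The reading for compound 3 is a limit, not a number: the limit of > 30000 nM in this assay, at which 1 of the 3 values shown sits.

As far as these compounds go, the full size of the step stays open. Also open, from the compounds shown here alone, are whether (morpholin-4-yl)methyl or (dimethylamino)methyl here would stay close to compound 1, and whether diethylamino would have a similar effect with the trifluoromethyl of compound 2 present.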